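A few compounds are considered here, and "the series" means these few. Any claim that something is new, unique, unknown or untested is made for them only; others in the source may bear on it.

In a functional assay on Huh-7 cells (Homo sapiens) for inhibition, read by MTT assay, with a stated time of 72 h (a lower number here means a stronger inhibitor, a higher number a weaker inhibitor), compound 3 `Nc1nc2cc(-c3nn(CCCCC(=O)NO)c4ncnc(N)c34)ccc2o1` gives 9220 nM and compound 1 `Nc1ncnc2c1c(-c1cnc3[nH]ccc3c1)nn2CCCCCCCCC(=O)NO` gives 7380 nM, two values within the scatter of each other. Compound 2 `Nc1ncnc2c1c(-c1cnc3[nH]ccc3c1)nn2CCCCCC(=O)NO` reads > 100000 nM, which is a limit of the assay. Compound 4 `Nc1nc2cc(-c3nn(CCCCCCCCC(=O)NO)c4ncnc(N)c34)ccc2o1` has 4-(hydroxycarbamoyl)butyl in place of hydroxycarbamoyl on a saturated chain carbon, four bonds along the chain from an aromatic nitrogen. Among the measured compounds shown here, the only measured step on chain length is an at least 13-fold higher number from compound 1 to compound 2 (1.13 log units; beyond the scatter), a large one, on a different core and in the shortening sense. Compound 4 lengthens the chain, so a moderate move to a lower number in this assay is expected, resting on that single pair. The expected change is a 3.1-fold lower number from compound 3 to compound 4 (0.49 log units; beyond the scatter). For compound 4 the estimated value is 3000 nM, with an expected range of 700 nM to 11000 nM.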

Compound 4, half-maximal inhibitory concentration: 1470 nM
Estimate against measurement, compound 4: 2.0-fold (0.31 log units) above; measured number inside the range.
By their numbers in this assay, from the lowest: compound 4; then compounds 1 and 3 (each within the scatter of the next). At a limit, above all of these: compound 2.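

In this assay, among the compounds shown here, 4-(hydroxycarbamoyl)butyl in place of hydroxycarbamoyl, on a saturated chain carbon, gives a 6.3-fold lower number from compound 3 to compound 4 (0.80 log units; beyond the scatter), the first chain step here measured as a number at both ends. The earlier chain step ended in a limit for compound 2. With the chain held, the group change on the aromatic carbon gives a 5.0-fold lower number from compound 1 to compound 4 (0.70 log units; beyond the scatter), so that group also moves the number at this chain length.

Nothing shown accounts for either step. As far as these compounds go, whether a still longer chain continues the trend, or a carboxylic acid in place of the hydroxycarbamoyl end keeps the activity, remains open.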